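Sulfonamide chain in place of cyclopropyl amide

A few compounds are considered here, and "the series" means these few. Any claim that something is new, unique, unknown or untested is made for them only; others in the source may bear on it.

Measured compounds:
- Compound 1, `C/C(=C\C(=O)Nc1ccc2nc(N3CCC(O)CC3)nc(C)c2c1)c1ccc(Cl)cc1`: 227 nM
- Compound 2, `COCCC1(O)CCN(c2nc(C)c3cc(NC(=O)/C=C/c4ccc(Cl)cc4)ccc3n2)CC1`: 220 nM
- Compound 3, `Cc1nc(NCCNC(=O)C2CC2)nc2ccc(NC(=O)/C=C/c3ccc(OC(F)(F)F)cc3)cc12`: 23 nM

In a functional assay on CHO-K1 cells for antagonist activity at melanin-concentrating hormone receptor 1 (Homo sapiens), read by inositol phosphate accumulation, with stated times of 10 min and 45 min (on this read-out higher numbers stand for weaker inhibition and lower numbers for stronger inhibition), compound 3 gives 23 nM, the lowest of the three numbers shown. Compound 2 gives 220 nM and compound 1 gives 227 nM, both beyond the scatter from compound 3, so compound 3 stands as the strongest inhibitor of this small set.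

Compound 4, `Cc1nc(NCCCNS(C)(=O)=O)nc2ccc(NC(=O)/C=C/c3ccc(OC(F)(F)F)cc3)cc12`, differs from compound 3 in one place: (methanesulfonamido)methyl in place of (cyclopropylcarbonyl)amino on a saturated chain carbon, two bonds along the chain from a nitrogen on an aromatic ring. The leaving and entering groups match in heavy-atom count and each carries one hydrogen-bond donor, while the entering group brings one more hydrogen-bond acceptor and no ring. Among the measured compounds shown here, no pair of measured compounds shows this kind of exchange, so there is no measured step to lean on. The expectation is that the step from compound 3 to compound 4 in this assay, a 1.5-fold higher number from compound 3 to compound 4 (0.18 log units; within the scatter), stays within or close to the scatter, with a slight lean toward a weaker number. Compound 4 is therefore estimated at 35 nM, with a range from 10 nM to 120 nM.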

Compound 4, half-maximal inhibitory concentration: 32 nM
Estimate against measurement, compound 4: 1.1-fold (0.04 log units) above; low and high end bracket the measured number.
By their numbers in this assay, from the lowest: compounds 3 and 4 (each within the scatter of the next); then compounds 2 and 1 (each within the scatter of the next).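

In this assay, putting (methanesulfonamido)methyl in place of (cyclopropylcarbonyl)amino on a saturated chain carbon, two bonds along the chain from a nitrogen on an aromatic ring, gives a 1.4-fold higher number from compound 3 to compound 4 (0.14 log units; within the scatter). Among the compounds shown here, this is the first measured step at this place, and it shows that the three-membered ring can go and a sulfonamide can stand in place of the amide with no change that can be told from the scatter. Nothing measured here explains why the number holds.

Going by these compounds, the chain and its end group change together in this one step, so the share of each stays open. The compounds shown also leave open whether a carboxylic acid or a dimethylamino group at the end of this chain would be held as well.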